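Swapping a propyl for a ribose-like sugar on a purine thioether

This account rests on a few compounds, and the source may have more. Where it says the series, first, only, none or still open, it means among the compounds named here.

Compound 1: `Nc1nc(SCc2ccccc2Cl)c2ncn([C@@H]3O[C@H](CO)[C@@H](O)[C@H]3O)c2n1`, 13500 nM
Compound 2: `CCCn1cnc2c(SCc3ccccn3)nc(N)nc21`, 91200 nM

In an assay on isolated protein for binding affinity to Equilibrative nucleoside transporter 1 (Homo sapiens) (on this read-out higher numbers stand for weaker inhibition and lower numbers for stronger inhibition), compound 2 gives 91200 nM, the highest number of the two measured, while compound 1 gives 13500 nM; the two differ in more than one place, so their gap is noted without being assigned to either change. Compound 3, `Nc1nc(SCc2ccccn2)c2ncn([C@@H]3O[C@H](CO)[C@@H](O)[C@H]3O)c2n1`, is not yet measured. It differs from compound 2 in one place only: 3,4-dihydroxy-5-(hydroxymethyl)oxolan-2-yl in place of propyl on an aromatic nitrogen. Going by the values given here, no pair that differs in just this place has been measured, so the size of the step is open. Among the compounds with values here, the only other compound that carries this sugar, compound 1, sits at the lower number, which gives a weak hint but no basis for a firm direction. Compound 3 is therefore expected to land modestly lower, with a wide range, the step from compound 2 being estimated at a 3.6-fold lower number from compound 2 to compound 3 (0.56 log units; beyond the scatter), and its value at 25000 nM between 6000 nM and 120000 nM.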

Compound 3, half-maximal inhibitory concentration: 34700 nM
For compound 3 the middle estimate is 1.4-fold (0.14 log units) below the measured one, and the stated range covers the measured number.
By their numbers in this assay, from the lowest: compound 1; then compound 3; then compound 2.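

In this assay, the sugar's effect at this position can now be read on its own: 3,4-dihydroxy-5-(hydroxymethyl)oxolan-2-yl in place of propyl on the aromatic nitrogen gives a modest step (a 2.6-fold lower number from compound 2 to compound 3 (0.42 log units; beyond the scatter)). Compound 3 also ties compound 1 to this comparison, showing that pyridin-2-yl in place of 2-chlorophenyl on the saturated chain carbon bound to a sulfur matters too, with a modest step in the other direction (a 2.6-fold higher number from compound 1 to compound 3 (0.41 log units; beyond the scatter)). Nothing available explains either step.

The compounds shown leave open whether the sugar and the 2-chlorophenyl group act independently, as a compound pairing propyl with 2-chlorophenyl would show. They also leave open how a butyl chain or a simple hydroxyethyl chain on the same nitrogen would compare with propyl and the sugar.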